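A Trifluoromethyl Swap on a Tolerated Compound

A few compounds are considered here, and "the series" means these few. Any claim that something is new, unique, unknown or untested is made for them only; others in the source may bear on it.

In an ADME assay on L6 cells (Rattus norvegicus) for cytotoxicity, read by fluorescence and resazurin assay, with a stated time of 72 h (a lower number here means that less compound is tolerated, a higher number that more compound is tolerated), compound 1 (`CC(C)(C)c1ccc(-c2c[nH]cc2C(c2ccc(Cl)cc2Cl)n2ccnc2)cc1`) gives 22900 nM and compound 2 (`O=[N+]([O-])c1ccc(-c2c[nH]cc2C(c2ccc(Cl)cc2Cl)n2ccnc2)cc1`) gives 16900 nM so the two stand within the scatter of each other. Compound 3 (`FC(F)(F)c1ccc(-c2c[nH]cc2C(c2ccc(Cl)cc2Cl)n2ccnc2)cc1`) differs from compound 1 by trifluoromethyl in place of tert-butyl on an aromatic carbon with trifluoromethyl in place of tert-butyl on an aromatic carbon. Among the measured compounds shown here, the only measured step that replaces the same tert-butyl puts nitro there, and it amounts to a 1.4-fold lower number from compound 1 to compound 2 (0.13 log units; within the scatter) which stays within the scatter. For the measured compounds named here, one step is thin evidence, and no measured compound yet carries trifluoromethyl, but nothing measured points to a shift in either direction. The expected move is a 1.2-fold lower number from compound 1 to compound 3 (0.07 log units; within the scatter) and so no step beyond the scatter is anticipated. In this assay the estimate for compound 3 is 19500 nM with an expected range from 10000 nM to 38000 nM around it.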

Compound 3, half-maximal cytotoxic concentration: 9400 nM
Compound 3: the middle estimate sits 2.1-fold (0.32 log units) above what was measured; the whole stated range lies above it.
By their numbers in this assay, from the lowest: compounds 3, 2 and 1 (each within the scatter of the next, the first and the last beyond it).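

In this assay, among the compounds shown here, replacing tert-butyl with trifluoromethyl at this place on the aromatic ring gives a 2.4-fold lower number from compound 1 to compound 3 (0.39 log units; beyond the scatter), the first step here to pass beyond the scatter, though only a modest one. Compound 2 and compound 3 remain within the scatter of each other, with a 1.8-fold lower number from compound 2 to compound 3 (0.25 log units; within the scatter), so the two replacements of tert-butyl cannot be separated, even though only the trifluoromethyl step from compound 1 passes beyond the scatter. No evidence is available that bears on this difference.

Going by these compounds, whether an amine, a carboxylic acid or a longer chain at the same place would stay close to compound 1 or fall further remains open. So does whether the step from tert-butyl to trifluoromethyl would hold if another part of the shared core were changed.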